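The source may hold more compounds than are shown below. What is called first, only, known or untested is meant among the compounds shown, and "the series" means these compounds.

Working notes on the furyl-substituted series. Compound 1 `Nc1nccn2cc(-c3ccco3)nc12` is the free amine on the shared core; compound 2 `O=C(Nc1nccn2cc(-c3ccco3)nc12)c1ccccc1` carries a benzamide on that amine. In an assay on cells for displacement of a labelled ligand from transmembrane domain-containing protein TMIGD3 (Homo sapiens), read by scintillation counting, with a stated time of 120 min, tested at 1 uM (on this read-out higher numbers stand for more inhibition at the one concentration tested (going by the name of the read-out) and lower numbers for less inhibition), compound 1 gives 5%, and in this assay compound 2 gives 22%. Among the measured compounds shown here, of the two numbers so far, compound 1 stands lowest, and the gap to compound 2 lies beyond the usual scatter of this read-out, so the amide does more here than the free amine. For the measured compounds named here, no step between compounds differing in one place has been worked out yet.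

Compound 3 `Nc1nc(Br)cn2cc(-c3ccco3)nc12` is the next entry, not yet measured in this assay. Relative to compound 1 the change is bromo in place of hydrogen on an aromatic carbon. On the information available, the expected step from compound 1 to compound 3 in this assay, a number 7 percentage points higher from compound 1 to compound 3 (within the scatter), is small, upward at most, and may well fall within the scatter. Compound 3 is estimated at 12% in this assay, with a range from 0% to 30%.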

Compound 3, a percentage reported as inhibition, at one concentration (the size of the read-out at that concentration, not a potency): 28%
Compound 3: middle estimate off by 16 percentage points, on the low side, and the stated range covers the measured number.
By their numbers in this assay, from the lowest: compound 1; then compounds 2 and 3 (each within the scatter of the next).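

The compound 1 and compound 2 pair spoke only to the amine; compound 3 shows that the shared core also responds at a ring carbon, with the free amine left in place. In this assay, bromo in place of hydrogen on an aromatic carbon next to the ring nitrogen and meta to an amino group gives a number 23 percentage points higher from compound 1 to compound 3 (beyond the scatter), so this position accepts a bromine atom and the read-out moves with it. Nothing on hand explains why this step occurs.

Going by these compounds, whether the step is specific to bromo stays open, since chloro, methyl, methoxy or a longer chain on this carbon would be needed to tell. Also open, on these data alone, is how bromo at this position and the benzamide on the amine behave together on one compound.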